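Cytotoxicity of three triazole analogues and an expected fourth

The source may report more compounds than this note shows. Statements on the series, on what has been measured and on what is new or still open speak of the compounds shown alone.

Measured compounds:
compound 1 `CCc1ccc(-n2nc(-c3ccc(C(F)(F)F)cc3O)nc2-c2ccccc2O)cc1` gives 95.4%
compound 2 `N#Cc1ccc(-n2nc(-c3ccc(C(F)(F)F)cc3O)nc2-c2ccccc2O)cc1` gives 86.8%
compound 3 `Oc1cc(C(F)(F)F)ccc1-c1nc(-c2ccccc2O)n(-c2ccccc2C(F)(F)F)n1` gives 80%

In a functional assay on PC-12 cells (Rattus norvegicus) for cytotoxicity, read by MTT assay, with stated times of 2 h and 24 h, tested at 5 uM (a lower number here means a weaker effect, a higher number a stronger effect of the compound at the concentration tested), compound 1 stands highest of the three numbers. Compound 2 lies nearest, and a number 8.6 percentage points lower from compound 1 to compound 2 (within the scatter) falls within the scatter. Compound 3 lies furthest, and a number 15.4 percentage points lower from compound 1 to compound 3 (beyond the scatter) is a modest step beyond the scatter, while a number 6.8 percentage points lower from compound 2 to compound 3 (within the scatter) stays within it.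

Compound 4 `Oc1cc(C(F)(F)F)ccc1-c1nc(-c2ccccc2O)n(-c2cc(F)cc(F)c2)n1` has not yet been measured. It differs from compound 1 in one place: 3,5-difluorophenyl in place of 4-ethylphenyl on an aromatic nitrogen. The step that bears most on it is the exchange of the aryl group on the same aromatic nitrogen from compound 1 to compound 3, which lowered the read-out modestly; the other two steps stayed within the scatter. A modest drop, or none beyond the scatter, is therefore expected for compound 4. The change from compound 1 to compound 4 is estimated as a number 10.4 percentage points lower from compound 1 to compound 4 (beyond the scatter). Compound 4 is expected to give about 85% in this assay, within a range from 70% to 97%.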

Compound 4, a percentage reported as activity, at one concentration (the size of the read-out at that concentration, not a potency): 100%
Beside the measured number, compound 4's estimate is 15 percentage points below it; measured number above the stated range.
By their numbers in this assay, from the lowest: compounds 3, 2, 1 and 4 (each within the scatter of the next, the first and the last beyond it).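

In this assay, the exchange of 4-ethylphenyl for 3,5-difluorophenyl on the aromatic nitrogen gives a number 4.6 percentage points higher from compound 1 to compound 4 (within the scatter), so a fluorinated ring without the ethyl group cannot be told apart from compound 1 at this position. The same group also separates from the two other aryl groups, with a number 20 percentage points higher from compound 3 to compound 4 (beyond the scatter) and a number 13.2 percentage points higher from compound 2 to compound 4 (beyond the scatter), whereas compound 1 stood clear of compound 3 only, which makes compound 4 the first of the series beyond the scatter from compound 2. Nothing available explains why these aryl groups differ in this way.

The compounds leave open how a benzyl group or a butyl chain on this nitrogen, or an amine or a carboxylic acid on its aryl ring, would compare. Read at one concentration, they also give no potency for any of the four.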